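A few compounds are considered here, and "the series" means these few. Any claim that something is new, unique, unknown or untested is made for them only; others in the source may bear on it.

Compound 1 `COc1ccc(NC(=O)Nc2cc(C)nc3ccccc23)cc1`: in an ADME assay on Raji cells (Homo sapiens) for cytotoxicity, with a stated time of 72 h (on this read-out higher numbers stand for an effect only at larger amounts of compound and lower numbers for an effect already at smaller amounts), compound 1 gives > 25000 nM, a limit of the assay.
Compound 2 `CC(=O)c1ccc(NC(=O)Nc2cc(C)nc3ccccc23)cc1`: in this assay compound 2 gives > 25000 nM, again only a limit.
Compound 3 `Cc1cc(NC(=O)Nc2ccc(Cl)cc2)c2ccccc2n1`: in this assay compound 3 gives > 25000 nM, a limit as well.

Compound 3 therefore stands nowhere in particular: it rests at the limit of > 25000 nM in this assay, at which 3 of the 3 values shown sit, together with the other two. The change to compound 4 `CCc1ccc(NC(=O)Nc2cc(C)nc3ccccc23)cc1` is ethyl in place of chloro on an aromatic carbon. Among the measured compounds shown here, the steps that bear on it, a step that the two limits leave unreadable from compound 1 to compound 3, a step that the two limits leave unreadable from compound 2 to compound 3 and a step that the two limits leave unreadable from compound 1 to compound 2, are all unreadable, since both ends of each sit at the limit. No size or direction in this assay can be drawn from them. Compound 4 is accordingly expected to stay at the limit, a step that the limit leaves unreadable from compound 3 to compound 4, with an estimate of 30000 nM in a range from 10000 nM to 100000 nM.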

Compound 4, half-maximal effective concentration: > 25000 nM
Compound 4: only a limit was reported; the forecaster's own chance of this, stated with the estimate: 85%; the middle value does not contradict the limit.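

In this assay compound 4 gives > 25000 nM, again only a limit. Its steps from compound 1, compound 2 and compound 3 therefore cannot be read: the limit of > 25000 nM in this assay, at which 4 of the 4 values shown sit.

The compounds shown leave open whether any change at this place alters the read-out, and in which direction.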